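This account rests on a few compounds, and the source may have more. Where it says the series, first, only, none or still open, it means among the compounds named here.

Measured so far in a functional assay on SMMC-7721 cells (Homo sapiens) for antiproliferative activity, read by MTT assay, with a stated time of 48 h; on this read-out lower numbers stand for stronger inhibition and higher numbers for weaker inhibition:
compound 1 `C=C1/C=C/C(=O)/C(CO)=C\C[C@](C)(CCC=C(C)C)/C=C/[C@H]1OC(=O)C=C(C)C` gives 4300 nM
compound 2 `CC(C)=CCC[C@]1(C)/C=C/[C@@H](OC(=O)C=C(C)C)[C@](C)(O)/C=C/C(=O)/C(C(=O)O)=C\C1` gives > 10000 nM
compound 3 `CC(C)=CCC[C@]1(C)/C=C/[C@@H](OC(=O)C=C(C)C)[C@](C)(O)/C=C/C(=O)/C(C[Si](c2ccccc2)(c2ccccc2)C(C)(C)C)=C\C1` gives 38000 nM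

The reading for compound 2 is a limit of the assay, not a number; compound 2 therefore stands at the limit of > 10000 nM in this assay, at which 1 of the 3 values shown sits, and its exact place among the three is not fixed. Of the two compounds that carry numbers, compound 1 gives the lower reading in this assay and compound 3 the higher one.

Among the measured compounds shown here, no step between measured compounds that differ in a single place is recorded, so the change leading to compound 4 `CC(C)=CCC[C@]1(C)/C=C/[C@@H](OC(=O)C=C(C)C)[C@](C)(O)/C=C/C(=O)/C(Cn2cc(CO)nn2)=C\C1` is judged from the structures and the two numbers alone. Compound 4 differs from compound 2 in one place: (4-(hydroxymethyl)-1H-1,2,3-triazol-1-yl)methyl in place of carboxy on a double-bonded ring carbon.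

Since compound 2 is known only as a limit, a step from it can be bounded on one side only. Compound 1 at 4300 nM and compound 3 at 38000 nM mark the region in which the other members of this series have fallen, and compound 4 is expected to land in the same broad region. The step from compound 2 to compound 4 is expected to be a step that the limit leaves unreadable from compound 2 to compound 4, with its direction uncertain. Compound 4 is estimated at 15000 nM, within a range from 4000 nM to 50000 nM.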

Compound 4, half-maximal inhibitory concentration: 3560 nM
Compound 4: the middle estimate sits 4.2-fold (0.62 log units) above what was measured, outside the stated range (below it).
By their numbers in this assay, from the lowest: compounds 4 and 1 (each within the scatter of the next); then compound 3.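

In this assay, placing (4-(hydroxymethyl)-1H-1,2,3-triazol-1-yl)methyl in place of carboxy on the double-bonded ring carbon gives an at least 2.8-fold lower number from compound 2 to compound 4 (0.44 log units; beyond the scatter). This shows that the position can carry a substituent with a five-membered aromatic ring and more heavy atoms than carboxy while the reading falls, and the size of the step is fixed on one side only, since the reading for compound 2 is a limit of the assay: the limit of > 10000 nM in this assay, at which 1 of the 4 values shown sits. At this same ring carbon compound 3 differs from compound 4; compound 3 gives 38000 nM, whereas compound 4 gives 3560 nM, so what this position holds clearly matters to the reading in this assay.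

The compounds shown do not separate the part played by the triazole ring from that of its hydroxymethyl group, and the true size of the step remains unknown. On these data alone, it also remains open how the reading would respond if an amine or a longer chain, such as a hydroxyethyl group, took the place of that hydroxymethyl group on the triazole.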